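This account rests on a few compounds, and the source may have more. Where it says the series, first, only, none or still open, it means among the compounds named here.

In an ADME assay on L929 cells (Mus musculus) for cytotoxicity, read by MTT assay, with a stated time of 24 h (a lower number here means that less compound is needed, a higher number that more compound is needed for the effect), compound 1 `COCCOCCOCCOCCOCCOCCOCCOCCOCCOCCOC(=O)Oc1c(C(C)C)cccc1C(C)C` gives 420000 nM and compound 2 `COCCOCCOCCOC(=O)Oc1c(C(C)C)cccc1C(C)C` gives 2290000 nM, so compound 2 stands at the highest of the two numbers, with compound 1 lower by more than the scatter. Compound 3 `COCCOCCOCCOCCOC(=O)Oc1c(C(C)C)cccc1C(C)C` differs from compound 2 by methoxymethyl in place of hydrogen on a saturated chain carbon bound to an oxygen on a saturated carbon. For this step the account expects the number to move down only slightly, likely within the scatter, because the much longer chain of compound 1 at 420000 nM sets the direction while the change here is one unit. Compound 3 is therefore estimated at 1700000 nM, between 900000 nM and 3200000 nM, a step of a 1.3-fold lower number from compound 2 to compound 3 (0.13 log units; within the scatter).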

Compound 3, half-maximal effective concentration: 1390000 nM
Beside the measured number, compound 3's estimate is 1.2-fold (0.09 log units) above it, within the range that was stated.
By their numbers in this assay, from the lowest: compound 1; then compounds 3 and 2 (each within the scatter of the next).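

Methoxymethyl in place of hydrogen on a saturated chain carbon bound to an oxygen on a saturated carbon gives a 1.6-fold lower number from compound 2 to compound 3 (0.22 log units; within the scatter) in this assay. Within the data shown here, this is the first change in a single place that can be read here, and at this position, this one change does not separate the two compounds. No evidence at hand bears on this result. On these data alone, it remains open whether a longer chain in place of methoxymethyl would give a step beyond the scatter, and what an amine or a carboxylic acid there would do.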